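Anilino series: hydroxy in place of methyl

A few compounds are considered here, and "the series" means these few. Any claim that something is new, unique, unknown or untested is made for them only; others in the source may bear on it.

Measured so far:
compound 1, `O=C1CCC(N2C(=O)c3ccc(Nc4ccccc4)cc3C2=O)C(=O)N1`, giving 6% in an assay on FRT-Jurkat cells for inhibition of nuclear factor NF-kappa-B complex (Homo sapiens), read by flow cytometry, with a stated time of 24 h, tested at 10 uM; on this read-out higher numbers stand for more inhibition at the one concentration tested (going by the name of the read-out) and lower numbers for less inhibition
compound 2, `Cc1ccc(Nc2ccc3c(c2)C(=O)N(C2CCC(=O)NC2=O)C3=O)cc1`, giving 5% in this assay

Compound 2 holds the lowest of the two numbers in this assay, but the step of a number 1 percentage points lower from compound 1 to compound 2 (within the scatter) lies within the scatter, so the two compounds cannot be placed in order; both sit near the floor of the read-out.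

Compound 3, `O=C1CCC(N2C(=O)c3ccc(Nc4ccc(O)cc4)cc3C2=O)C(=O)N1`, differs from compound 2 by hydroxy in place of methyl on an aromatic carbon. For the measured compounds named here, no measured step exchanges a methyl for a hydroxy on this ring, and the one step that does touch the same ring, methyl in place of hydrogen, gave a number 1 percentage points lower from compound 1 to compound 2 (within the scatter). Going by the values given here, with both measured numbers near the floor and the only available step within the scatter, no movement beyond the scatter is expected; the expected step is a number 1 percentage points higher from compound 2 to compound 3 (within the scatter). Compound 3 is accordingly estimated at 6%, with a range from -8% to 22%.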

Compound 3, a percentage reported as inhibition, at one concentration (the size of the read-out at that concentration, not a potency): 4%
Compound 3: middle estimate off by 2 percentage points, on the high side, within the range that was stated.
By their numbers in this assay, from the lowest: compounds 3, 2 and 1 (each within the scatter of the next).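

On the aromatic carbon para to a large group, hydroxy in place of methyl brings in a hydrogen-bond donor and a hydrogen-bond acceptor, yet this assay shows a number 1 percentage points lower from compound 2 to compound 3 (within the scatter), and hydroxy in place of hydrogen shows a number 2 percentage points lower from compound 1 to compound 3 (within the scatter). Hydrogen, methyl and hydroxy at this place therefore cannot be told apart on this read-out, and all three compounds stay near its floor. Nothing at hand offers an explanation for this flat result.

As far as these compounds go, whether an amine, a carboxylic acid or a longer chain at this place would give a step beyond the scatter stays open. Also open, from the compounds shown here alone, is whether any change elsewhere on the shared core would lift the numbers from the floor, which would give this position a readable range.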